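Propargylamine series: removing the tertiary nitrogen substituent

A few compounds are considered here, and "the series" means these few. Any claim that something is new, unique, unknown or untested is made for them only; others in the source may bear on it.

Working notes on a short set of propargylamine-bearing analogues tested in an assay on isolated protein for inhibition of Amine oxidase [flavin-containing] A (Homo sapiens), read by fluorescence and Amplex Red, with a stated time of 15 min; a lower number here means a stronger inhibitor, a higher number a weaker inhibitor.

Compound 1 is `C#CCN(CC)Cc1cn(-c2cc(NC(=S)NCC)ncn2)cn1`. In this assay compound 1 reaches only the limit > 50000 nM. Compound 2 is `C#CCN(Cc1cn(-c2cc(NC(=S)NCC)ncn2)cn1)C(C)=O`, the acetyl analogue. In this assay compound 2 likewise gives only the limit > 50000 nM. Compound 3 is `C#CCN(CC#N)Cc1cn(-c2cc(NC(=S)NCC)ncn2)cn1`. In this assay compound 3 also stops at the limit > 50000 nM. The steps a step that the two limits leave unreadable from compound 1 to compound 2, a step that the two limits leave unreadable from compound 1 to compound 3 and a step that the two limits leave unreadable from compound 2 to compound 3 are therefore unreadable, since the limit of > 50000 nM in this assay, at which 3 of the 3 values shown sit, covers every value recorded so far.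

Compound 4 is `C#CCNCCCc1cn(-c2cc(NC(=S)NCC)ncn2)cn1`, the secondary amine in which the cyanomethyl is lost and the chain is lengthened: a group of 6 heavy atoms (5 carbon, 1 nitrogen; no ring) in place of a group of 7 heavy atoms (5 carbon, 2 nitrogen; no ring), on a saturated chain carbon bound to an aromatic carbon. Among the measured compounds shown here, no measured step bears on this change; the three steps recorded give no direction and no size. With every neighbour at the limit, compound 4 is expected to show a step of about a number no higher from compound 3 to compound 4 (the limit leaves the size open), which can only be read if a number appears. The estimate for compound 4 in this assay is 50000 nM, with a range from 10000 nM to 100000 nM, and the most likely outcome remains a limit.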

Compound 4, half-maximal inhibitory concentration: > 50000 nM
Compound 4: a limit, no number; the forecaster's own chance of this, stated with the estimate: 60%; the middle value sits exactly at the limit.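

In this assay compound 4 gives only the limit > 50000 nM, so its steps from compound 1, compound 2 and compound 3 cannot be read: the limit of > 50000 nM in this assay, at which 4 of the 4 values shown sit.

The compounds shown leave open whether any of these changes on the shared core alters inhibition, and in which direction.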